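Working notes: compound 4 next to compounds 1 to 3

The compounds below may be only part of what the source reports. "The series", "measured", "known", "first", "only" and "open" are said of these compounds alone.

Compound 1 `COCc1cccc(C[C@H](O)/C=C/[C@H]2[C@H](O)CC(=O)[C@@H]2SCCCSCC(=O)O)c1` gives > 10000 nM in an assay on CHO cells for displacement of a labelled ligand from prostaglandin E2 receptor EP1 subtype (Mus musculus) (on this read-out lower numbers stand for stronger inhibition and higher numbers for weaker inhibition), a limit of the assay.
Compound 2 `CCOCc1cccc(C[C@H](O)/C=C/[C@H]2[C@H](O)CC(=O)[C@@H]2SCCCSCC(=O)O)c1` gives > 10000 nM in this assay, a limit of the assay.
Compound 3 `COc1ccccc1C[C@H](O)/C=C/[C@H]1[C@H](O)CC(=O)[C@@H]1SCCCSCC(=O)O` gives > 10000 nM in this assay, a limit of the assay.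

Compound 3 stands at the limit, and so do the two other measured compounds; no numbered value exists in the series. The steps a step that the two limits leave unreadable from compound 1 to compound 2, a step that the two limits leave unreadable from compound 1 to compound 3 and a step that the two limits leave unreadable from compound 2 to compound 3 are all unreadable in size, the reason being (the limit of > 10000 nM in this assay, at which 3 of the 3 values shown sit).

Compound 4 `COc1ccc(C[C@H](O)/C=C/[C@H]2[C@H](O)CC(=O)[C@@H]2SCCCSCC(=O)O)cc1` differs from compound 3 by 4-methoxyphenyl in place of 2-methoxyphenyl on a saturated chain carbon, two bonds along the chain from a double-bonded chain carbon and an oxygen on a saturated carbon. Among the compounds with values here, none of the measured steps involves a 4-methoxyphenyl group, and the three measured steps give no readable size, so nothing among the measured compounds fixes the direction of the change from compound 3 to compound 4 in this assay.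

Compound 4 is therefore expected to sit at or near the same limit, and the estimated step of a number no higher from compound 3 to compound 4 (the limit leaves the size open) is taken as none beyond the scatter. The estimate for compound 4 is 10000 nM, with a range from 2500 nM to 40000 nM.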

Compound 4, inhibition constant: 3100 nM
Compound 4: middle estimate off by 3.2-fold (0.51 log units), on the high side; the measured number falls inside the stated range.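

In this assay, within the data shown here, 4-methoxyphenyl in place of 2-methoxyphenyl at this saturated chain carbon gives an at least 3.2-fold lower number from compound 3 to compound 4 (0.50 log units; beyond the scatter), the first readable step, from two groups that differ only in how the same atoms are joined. The same group in place of 3-(ethoxymethyl)phenyl gives an at least 3.2-fold lower number from compound 2 to compound 4 (0.50 log units; beyond the scatter), and in place of 3-(methoxymethyl)phenyl it gives an at least 3.2-fold lower number from compound 1 to compound 4 (0.50 log units; beyond the scatter). The steps among compounds 1, 2 and 3 cannot be read, and the three new steps give only a smallest size, because those three compounds sit at a limit: the limit of > 10000 nM in this assay, at which 3 of the 4 values shown sit.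

From the compounds shown here alone, it remains open whether the lower number needs the methoxy group itself, which a plain phenyl or a chlorine in place of that methoxy would test. Going by these compounds, it is also open where 3-methoxyphenyl would fall relative to compound 4.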